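An amino group on the shared core of compound 2

This account rests on a few compounds, and the source may have more. Where it says the series, first, only, none or still open, it means among the compounds named here.

Compound 2 `CC(C)c1ccccc1-c1nccc(NCc2ccc(-c3cccnc3)cc2)n1`: 150 nM
Compound 3 `Cc1cc(NCc2ccc(-c3cccnc3)cc2)nc(-c2ccccc2C(C)C)n1`: 210 nM
Compound 1 `FC(F)(F)c1ccccc1-c1nc(NCc2ccc(-c3cncnc3)cc2)c2ccccc2n1`: 3000 nM

These three numbers come from an assay on a protein complex for inhibition of ubiquitin carboxyl-terminal hydrolase 1/WD repeat-containing protein 48 (Homo sapiens), read by fluorescence; a lower number here means a stronger inhibitor, a higher number a weaker inhibitor. Among them, compound 2 has the lowest number; compound 3 sits a 1.4-fold higher number from compound 2 to compound 3 (0.15 log units; within the scatter) away, a change within the scatter, while compound 1 lies furthest, at a markedly higher number. Compound 4 `CC(C)c1ccccc1-c1ncc(N)c(NCc2ccc(-c3cccnc3)cc2)n1` differs from compound 2 by amino in place of hydrogen on an aromatic carbon. Among the compounds with values here, no measured pair shares this change. Within the data shown here, the only single-point step among the measured compounds, a 1.4-fold higher number from compound 2 to compound 3 (0.15 log units; within the scatter), concerns a methyl on an aromatic carbon of the shared core and stayed within the scatter; it is the only guide here, and it speaks to a different group at a different position. The expectation for compound 4 is therefore no step beyond the scatter, no change at the digits printed from compound 2 to compound 4 (within the scatter), with a wide range reflecting the lack of a closer precedent. Compound 4 is estimated at 150 nM, between 50 nM and 450 nM.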

Compound 4, half-maximal inhibitory concentration: 310 nM
Compound 4: middle estimate off by 2.1-fold (0.32 log units), on the low side, within the range that was stated.
By their numbers in this assay, from the lowest: compounds 2, 3 and 4 (each within the scatter of the next, the first and the last beyond it); then compound 1.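

In this assay the amino group, placed on an aromatic carbon ortho to a large group and two atoms from the ring nitrogen, gives a step beyond the scatter (a 2.1-fold higher number from compound 2 to compound 4 (0.32 log units; beyond the scatter)), which is modest in size. This is the first single change among these compounds to pass the scatter, so this position does respond to substitution, although an amino group in place of hydrogen costs little. Nothing available explains why the number rises with this change.

The compounds shown leave open whether a methylamino group, an acetamido group or a hydroxyl on this same carbon would give a similar step. They also leave open whether the amino group would have the same effect on a core that carries the methyl of compound 3.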